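Swapping trifluoromethyl for methoxy on a weak anilide

This account rests on a few compounds, and the source may have more. Where it says the series, first, only, none or still open, it means among the compounds named here.

Measured compounds:
Compound 1, `O=C(Nc1ccc(C(F)(F)F)cc1)C1CCc2ccccc2N1`: 20300 nM
Compound 2, `CCCCCCCCC(=O)N1c2ccccc2CCC1C(=O)Nc1ccccc1C(F)(F)F`: 4320 nM
Compound 3, `O=C(Nc1ccccc1C(F)(F)F)C1CCc2ccccc2N1C(=O)c1cccc(Cl)c1`: 729 nM

Three compounds share a core and were tested in a functional assay on PC-3 cells (Homo sapiens) for cytotoxicity, read by sulforhodamine B assay, with a stated time of 72 h; a higher number here means a weaker inhibitor of growth, a lower number a stronger inhibitor of growth. Compound 1, with a free ring nitrogen and an anilide bearing trifluoromethyl, gives 20300 nM, the highest number of the three. Among the measured compounds shown here, compound 2 adds an octanoyl group on that nitrogen and gives 4320 nM, and compound 3 carries a benzoyl group with chlorine instead and gives 729 nM; the step of a 5.9-fold lower number from compound 2 to compound 3 (0.77 log units; beyond the scatter) is the only one-place comparison among the measured compounds.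

Compound 4, `COc1ccc(NC(=O)C2CCc3ccccc3N2)cc1`, differs from compound 1 by the change (methoxy in place of trifluoromethyl on an aromatic carbon). For the measured compounds named here, no measured step touches this part of the molecule: the step from compound 2 to compound 3 concerns the group on the ring nitrogen, not the anilide ring. The expectation therefore rests on compound 1 alone, with no basis for a shift beyond the scatter in either direction. Compound 4 is estimated at 25000 nM, within 8000 nM to 80000 nM, which amounts to an expected step of a 1.2-fold higher number from compound 1 to compound 4 (0.09 log units; within the scatter).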

Compound 4, concentration for 50% growth inhibition: 56900 nM
Beside the measured number, compound 4's estimate is 2.3-fold (0.36 log units) below it; measured number inside the range.
By their numbers in this assay, from the lowest: compound 3; then compound 2; then compound 1; then compound 4.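

This position on the anilide ring, para to a large group, is not indifferent: methoxy in place of trifluoromethyl gives a 2.8-fold higher number from compound 1 to compound 4 (0.45 log units; beyond the scatter) and so weaker growth inhibition. Among the compounds shown here, the earlier step concerned only the group on the ring nitrogen, so this is the first measured sign that the anilide ring can also move the number, though only in a compound with a free ring nitrogen. Nothing measured here explains why the number moves in this direction.

Two groups cannot show whether this position follows any trend, and a chlorine, a nitrile or a hydroxyl there could fall on either side of them. As far as these compounds go, it also remains open whether the same swap would move the number similarly in a compound with an acyl group on the ring nitrogen, such as compound 3.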